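This account rests on a few compounds, and the source may have more. Where it says the series, first, only, none or still open, it means among the compounds named here.

Within the data shown here, compound 2 `CC(C)=CCc1cc(C(=O)Nc2cc3ccc(OCC4CCCNC4)c(C)c3oc2=O)ccc1O` stands alongside compound 1 `CC(C)=CCc1cc(C(=O)Nc2cc3ccc(OCCC4CCCCN4)c(C)c3oc2=O)ccc1O` as one of only two numbers measured in a functional assay on SK-BR-3 cells (Homo sapiens) for antiproliferative activity; on this read-out higher numbers stand for weaker inhibition and lower numbers for stronger inhibition: compound 2 gives 600 nM, compound 1 gives 640 nM, and the step of a 1.1-fold lower number from compound 1 to compound 2 (0.03 log units; within the scatter) leaves the two inseparable. Compound 3 `CCCN(CCC)CCCOc1ccc2cc(NC(=O)c3ccc(O)c(CC=C(C)C)c3)c(=O)oc2c1C` returns only a limit of the assay, > 50000 nM. The change to compound 4 `CC(C)=CCc1cc(C(=O)Nc2cc3ccc(OCCCN(C)C(C)(C)C)c(C)c3oc2=O)ccc1O` is 2-(methyl(tert-butyl)amino)ethyl in place of piperidin-3-yl on a saturated chain carbon bound to an oxygen on an aromatic ring. The measured steps that bear on it are those where a piperidine fragment gives way to a dipropylamino group with no ring: an at least 83-fold higher number from compound 2 to compound 3 (1.92 log units; beyond the scatter) and an at least 78-fold higher number from compound 1 to compound 3 (1.89 log units; beyond the scatter), both ending at the limit of > 50000 nM in this assay, at which 1 of the 3 values shown sits. Compound 4 likewise carries a chain amine with no ring, so a large increase in the number is expected, quite possibly reaching the limit again. Compound 4 is therefore estimated at 20000 nM, with a range from 3000 nM to 50000 nM, which means an expected step of a 33-fold higher number from compound 2 to compound 4 (1.52 log units; beyond the scatter).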

Compound 4, half-maximal inhibitory concentration: 880 nM
Compound 4: the middle estimate sits 23-fold (1.36 log units) above what was measured; the whole stated range lies above it.
By their numbers in this assay, from the lowest: compounds 2, 1 and 4 (each within the scatter of the next). At a limit, above all of these: compound 3.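

In this assay a ring is not required in this group: with a 1.5-fold higher number from compound 2 to compound 4 (0.17 log units; within the scatter) and a 1.4-fold higher number from compound 1 to compound 4 (0.14 log units; within the scatter) as the steps, compound 4 cannot be told apart from the two piperidine compounds, even though its 2-(methyl(tert-butyl)amino)ethyl group has no ring and 0 hydrogen-bond donors. Compound 3 gives > 50000 nM as a limit of the assay. Changing only the amine on the same chain gives an at least 56-fold lower number from compound 3 to compound 4 (1.75 log units; beyond the scatter) with methyl(tert-butyl)amino in place of dipropylamino, so the loss seen in compound 3 goes with that particular amine and not simply with the lack of a ring.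

From the compounds shown here alone, whether a dimethylamino, diethylamino or pyrrolidine group on this chain would behave like compound 4 or like compound 3 stays open. So does the outcome for a longer chain, such as butyl, carrying methyl(tert-butyl)amino.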